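Nitrofuran amide series: cyclopropylcarbonyl analogue, cytotoxicity estimate

The source may report more compounds than this note shows. Statements on the series, on what has been measured and on what is new or still open speak of the compounds shown alone.

Measured so far:
Compound 1 `CC(=O)Nc1cccc(-c2csc(NC(=O)c3ccc([N+](=O)[O-])o3)n2)c1` in an ADME assay on Vero cells (Chlorocebus sabaeus) for cytotoxicity, read by MTT assay, with a stated time of 72 h (on this read-out higher numbers stand for weaker inhibition and lower numbers for stronger inhibition), gives 57600 nM.
Compound 2 `Nc1cccc(-c2csc(NC(=O)c3ccc([N+](=O)[O-])o3)n2)c1` in this assay gives "not determined" (no result reported), so no result is reported for it.

Compound 2 therefore stands nowhere on the numbers shown: its place in this assay is open, and the only anchor in the series is compound 1, whose value sits at a weakly cytotoxic level. Compound 3 `O=C(Nc1nc(-c2cccc(NC(=O)C3CC3)c2)cs1)c1ccc([N+](=O)[O-])o1` carries cyclopropylcarbonyl in place of hydrogen on a nitrogen on an aromatic ring, which makes it the closest relative of compound 1, differing only in the acyl group on that nitrogen.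

Going by the values given here, no step between measured compounds is available, so no direction can be read from the data. The expectation for this assay is a step of no size beyond the scatter relative to compound 1, given that compound 3 keeps the amide and the rest of the shared core unchanged. On that basis compound 3 is estimated at 50000 nM, with a range from 20000 nM to 120000 nM.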

Compound 3, half-maximal inhibitory concentration: 35700 nM
Compound 3: middle estimate off by 1.4-fold (0.15 log units), on the high side, and the stated range covers the measured number.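

In this assay, cyclopropyl and methyl on the carbonyl carbon are not separated by the read-out (a 1.6-fold lower number from compound 1 to compound 3 (0.21 log units; within the scatter)). With compound 3, the acylated nitrogen on the aromatic ring has two acyl groups on record, and a three-membered carbon ring at this carbonyl gives no step beyond the scatter. No evidence on any measured property bears on this result.

On these data alone, with no result for compound 2, the change from amino to (cyclopropylcarbonyl)amino cannot be read, so the effect of having an acyl group on this nitrogen at all remains open. Also open, as far as these compounds go, is whether a butanoyl chain, a benzoyl group or an acyl group carrying a carboxylic acid would stay within the scatter of compound 1 and compound 3 at this position.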